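This account rests on a few compounds, and the source may have more. Where it says the series, first, only, none or still open, it means among the compounds named here.

Measured compounds:
Compound 1: `CCN(Cc1c[nH]nn1)C(=O)COc1ccc(C)cc1`, 31100 nM in an assay on HEK293 cells for agonist activity at transient receptor potential cation channel subfamily M member 8 (Homo sapiens), read by fluorescence and calcium flux, with a stated time of 15 min; a lower number here means that less compound is needed, a higher number that more compound is needed for the effect
Compound 2: `CCN(Cc1cccs1)C(=O)COc1ccc(C(F)(F)F)cc1`, 236 nM in this assay

Compound 2 gives the lowest of the two numbers in this assay; compound 1 sits far higher, and that gap lies beyond the scatter. Compound 3, `CCN(Cc1cccs1)C(=O)COc1ccc(CO)cc1`, has not yet been measured. It differs from compound 2 in one place: hydroxymethyl in place of trifluoromethyl on an aromatic carbon. Among the measured compounds shown here, no measured pair shows this change, so its effect is unknown here. The expectation for compound 3 is a moderate rise in this assay, that is a weakening, amounting to a 13-fold higher number from compound 2 to compound 3 (1.10 log units; beyond the scatter). Compound 3 is therefore estimated at 3000 nM, with a range from 600 nM to 15000 nM.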

Compound 3, half-maximal effective concentration: 21900 nM
The estimate for compound 3 lay 7.3-fold (0.86 log units) below the measured number; measured number above the stated range.
By their numbers in this assay, from the lowest: compound 2; then compounds 3 and 1 (each within the scatter of the next).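

On the aromatic carbon para to a large group, the choice of substituent matters greatly: in this assay, hydroxymethyl in place of trifluoromethyl gives a 93-fold higher number from compound 2 to compound 3 (1.97 log units; beyond the scatter) as the first single-change comparison available. This large step shows that the activity of compound 2 does not survive this exchange. No measurement shown explains the size of the step.

Among the compounds shown here, with only this one pair, it remains open how a methoxy group, a chlorine atom or a nitrile would fare at this position. Whether the same exchange would have a similar effect on a different core is also unknown.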